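A few compounds are considered here, and "the series" means these few. Any claim that something is new, unique, unknown or untested is made for them only; others in the source may bear on it.

Measured in a functional assay on HepG2 cells (Homo sapiens) for antiproliferative activity, read by MTT assay, with a stated time of 72 h; on this read-out higher numbers stand for weaker inhibition and lower numbers for stronger inhibition:
- compound 1 `CCOC(=O)c1csc2nc(CN3CCN(C)CC3)c(-c3ccc(C)cc3)n12`: 53600 nM
- compound 2 `CCOC(=O)c1csc2nc(CN3CCN(C)CC3)c(-c3ccc(Br)cc3)n12`: 82700 nM
- compound 3 `Cc1ccc(-c2c(CN3CCCCC3)nc3scc(C(=O)O)n23)cc1`: 10800 nM

Of these three, compound 3 has the lowest number, and its gaps to compound 1 and compound 2 both lie beyond the scatter. Compound 4 `O=C(O)c1csc2nc(CN3CCCCC3)c(-c3ccc(Br)cc3)n12` differs from compound 3 by a single change: bromo in place of methyl on an aromatic carbon. This is bromo in place of methyl on an aromatic carbon, turning 4-methylphenyl into 4-bromophenyl. Among the compounds with values here, one measured step bears on it: the same exchange, made in a pair that differs from compound 3 elsewhere, gave a 1.5-fold higher number from compound 1 to compound 2 (0.19 log units; within the scatter). In this assay, a similarly small upward shift, not beyond the scatter, is therefore expected. The expected step is a 1.4-fold higher number from compound 3 to compound 4 (0.14 log units; within the scatter). The estimate for compound 4 is 15000 nM, with an expected range of 6500 nM to 35000 nM.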

Compound 4, half-maximal inhibitory concentration: > 100000 nM
Compound 4: no number, only a limit; the forecaster's own chance of this, stated with the estimate: 5%; at least 6.6-fold (0.82 log units) between middle value and limit.
By their numbers in this assay, from the lowest: compound 3; then compounds 1 and 2 (each within the scatter of the next). At a limit, above all of these: compound 4.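

In this assay, the exchange of 4-methylphenyl for 4-bromophenyl on the core of compound 3 gives an at least 9.2-fold higher number from compound 3 to compound 4 (0.96 log units; beyond the scatter). Compound 4 has only a limit of the assay, > 100000 nM, so this step has a floor but no exact size. The earlier pair alone did not show that the same exchange can read differently on another core: the same change on two cores in this assay, a 1.5-fold higher number (0.19 log units; within the scatter) from compound 1 to compound 2 and an at least 9.2-fold higher number (0.96 log units; beyond the scatter) from compound 3 to compound 4, at least 6.0-fold (0.77 log units) apart, beyond the scatter of two such steps

The compounds shown do not settle which part of the two cores goes with this difference. From the compounds shown here alone, how a chloro or methoxy group at this position would read also remains open.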